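The source may hold more compounds than are shown below. What is called first, only, known or untested is meant among the compounds shown, and "the series" means these compounds.

Working notes on the series.

Compound 1, `Cc1ccccc1S(=O)(=O)N1CC(O)C[C@H]1C(=O)Nc1ccc(C(=O)O)cc1`, is the starting point; in a functional assay on the whole organism for inhibition, with Rattus norvegicus as the target, read by paw edema, with stated times of 1 h and 3 h, at a dose of 100 mg/kg by the oral route (on this read-out higher numbers stand for more inhibition at the one dose given (going by the name of the read-out) and lower numbers for less inhibition), compound 1 gives 25.3%. Compound 2, `Cc1ccccc1S(=O)(=O)N1CCC[C@H]1C(=O)Nc1ccc(C(=O)O)cc1`, differs from it by hydrogen in place of hydroxy on a saturated ring carbon, and in this assay compound 2 gives 40.1%. The step is a number 14.8 percentage points higher from compound 1 to compound 2 (beyond the scatter). On the two numbers shown, compound 2 stands highest, with compound 1 the nearest number below it and that gap beyond the scatter.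

Compound 3, `Cc1ccc(S(=O)(=O)N2CCC[C@H]2C(=O)Nc2ccc(C(=O)O)cc2)cc1`, is not yet measured. It differs from compound 2 as follows: 4-methylphenyl in place of 2-methylphenyl on a sulfonyl sulfur. Within the data shown here, no measured step touches the substituent on the sulfonyl sulfur: the single step available concerns the saturated ring carbon and nothing else, so it gives no direct guide to this change. There is therefore no basis for expecting a step in this assay beyond the scatter in either direction, and the estimate for compound 3 rests on the number for compound 2.

The expected step is a number 0.1 percentage points lower from compound 2 to compound 3 (within the scatter), taken as within the scatter. Compound 3 is estimated at 40% in this assay. The expected range for compound 3 runs from 20% to 60%. Among the measured compounds shown here, that range is wide: no relevant step has been measured.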

Compound 3, a percentage reported as inhibition, in the whole organism at one dose (the size of the read-out at that dose, not a potency): 35.3%
Compound 3: middle estimate off by 4.7 percentage points, on the high side, within the range that was stated.
By their numbers in this assay, from the lowest: compounds 1, 3 and 2 (each within the scatter of the next, the first and the last beyond it).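

Among these compounds, the first measured change on the sulfonyl sulfur, 4-methylphenyl in place of 2-methylphenyl, gives a number 4.8 percentage points lower from compound 2 to compound 3 (within the scatter) in this assay. On this one pair, the read-out at the single dose does not separate the two groups, so the place of the methyl group on the phenyl ring shows no effect beyond the scatter, whereas the change on the saturated ring carbon gave a number 14.8 percentage points higher from compound 1 to compound 2 (beyond the scatter). No measured evidence bears on this result.

The compounds shown carry only these two methylphenyl groups on the sulfonyl sulfur, so it remains open whether unsubstituted phenyl, 4-chlorophenyl or a longer chain such as n-butyl in that place would give a number beyond the scatter from that of compound 2. As far as these compounds go, it also remains open whether the step seen on the saturated ring carbon holds with 4-methylphenyl on the sulfonyl sulfur, and how a primary amide in place of the carboxylic acid would read in this assay.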